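Swapping methoxy for cyano on two imine-ether scaffolds

A few compounds are considered here, and "the series" means these few. Any claim that something is new, unique, unknown or untested is made for them only; others in the source may bear on it.

Two pairs of compounds share one structural change. Compound 1 `COc1ccc(Cn2cc(CO/N=C/c3c(-c4ccc(C)cc4)nc4c(C)cccn34)nn2)cc1` and compound 3 `Cc1ccc(-c2nc3c(C)cccn3c2/C=N/OCc2cn(Cc3ccc(C#N)cc3)nn2)cc1` differ only by cyano in place of methoxy on an aromatic carbon. In a functional assay on the whole organism (strain NMRI) with Mus musculus as the target, with a stated time of 4 h (on this read-out higher numbers stand for an effect only at larger amounts of compound and lower numbers for an effect already at smaller amounts), compound 1 gives 100 mg/kg, and compound 3 gives 100 mg/kg; the measured step is no change at the digits printed from compound 1 to compound 3 (within the scatter). Compound 2 `COc1ccc(Cn2cc(CO/N=C/c3c(-c4ccccc4)nc4ccc(Br)cn34)nn2)cc1` is built on a different core; the difference between the cores of compound 1 and compound 2 is not broken down here. In this assay compound 2 gives 40 mg/kg, the lowest of the three measured numbers, and its gap to compound 1 and to compound 3 lies beyond the usual scatter. Compound 4 `N#Cc1ccc(Cn2cc(CO/N=C/c3c(-c4ccccc4)nc4ccc(Br)cn34)nn2)cc1` has not yet been measured; it differs from compound 2 by cyano in place of methoxy on an aromatic carbon, the same change as that between compound 1 and compound 3, at the same kind of place. Because the earlier step of no change at the digits printed from compound 1 to compound 3 (within the scatter) stayed flat, the expected step here is estimated as no change at the digits printed from compound 2 to compound 4 (within the scatter), small enough to sit within the scatter. Compound 4 is therefore expected to give about 40 mg/kg in this assay, with a likely range from 20 mg/kg to 100 mg/kg.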

Compound 4, minimum effective dose: 20 mg/kg
Beside the measured number, compound 4's estimate is 2.0-fold (0.30 log units) above it, and the stated range covers the measured number.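

In this assay, cyano in place of methoxy on the second core gives a 2.0-fold lower number from compound 2 to compound 4 (0.30 log units; within the scatter). Set beside the step on the first core, this step cannot be told apart from it: the same change on two cores in this assay, no change at the digits printed (within the scatter) from compound 1 to compound 3 and a 2.0-fold lower number (0.30 log units; within the scatter) from compound 2 to compound 4, 2.0-fold (0.30 log units) apart, within the scatter of two such steps

For these two pairs, then, the change carries from one core to the other without any step that stands clear of the usual scatter, but two pairs are too few to show that it would behave the same way on every core in this series, and they do not show why the numbers behave as they do.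

The compounds shown leave open what other groups would do at this same place on the aromatic ring, such as an amine, a carboxylic acid or a longer chain in place of the methoxy or cyano. Going by these compounds, it is also open whether the swap from 4-methoxybenzyl to 4-cyanobenzyl would stay within the scatter on cores other than these two.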